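Moving the Chlorine on a Shared Anilino Substituent

The source may hold more compounds than are shown below. What is called first, only, known or untested is meant among the compounds shown, and "the series" means these compounds.

Compound 1 `Clc1ccc(Nc2nc3ncccc3n2Cc2ccccc2)cc1` and compound 2 `Clc1cccc(Nc2nc3ncccc3n2Cc2ccccc2)c1` are built on one core, while compound 3 `Cn1nc(-c2ccnc(Nc3ccc(Cl)cc3)n2)c2ccccc21` carries a different core; the difference between the two cores is not broken down here. In a functional assay on MCF7 cells (Homo sapiens) for antiproliferative activity, read by MTT assay, with a stated time of 72 h (on this read-out higher numbers stand for weaker inhibition of growth and lower numbers for stronger inhibition of growth), compound 1 gives 48000 nM, and compound 2 gives 43500 nM. The change between them is 3-chlorophenyl in place of 4-chlorophenyl on a nitrogen on an aromatic ring, and it made a 1.1-fold lower number from compound 1 to compound 2 (0.04 log units; within the scatter). Compound 3 stands apart from both: in this assay compound 3 gives 7830 nM, the lowest of the three numbers, with compound 2 the nearest and compound 1 the furthest, and both of those gaps lie beyond the scatter.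

Compound 4 `Cn1nc(-c2ccnc(Nc3cccc(Cl)c3)n2)c2ccccc21` has not yet been measured. It differs from compound 3 by 3-chlorophenyl in place of 4-chlorophenyl on a nitrogen on an aromatic ring, the same change that separates compound 2 from compound 1; among the compounds shown, this change occurs twice, and its only measured instance is the step from compound 1 to compound 2. The expectation for compound 4 therefore rests on that measured step alone, because a 1.1-fold lower number from compound 1 to compound 2 (0.04 log units; within the scatter) lay within the scatter. One measured pair on a different core is a thin basis, so the range is kept wide. For compound 4 in this assay a value of 7000 nM is expected, between 3000 nM and 16000 nM. This amounts to an expected 1.1-fold lower number from compound 3 to compound 4 (0.05 log units; within the scatter), mirroring the measured 1.1-fold lower number from compound 1 to compound 2 (0.04 log units; within the scatter).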

Compound 4, concentration for 50% growth inhibition: 5970 nM
Compound 4: middle estimate off by 1.2-fold (0.07 log units), on the high side; measured number inside the range.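

Within the data shown here, on the second core, 3-chlorophenyl in place of 4-chlorophenyl on a nitrogen on an aromatic ring gave a 1.3-fold lower number from compound 3 to compound 4 (0.12 log units; within the scatter) in this assay, so moving the chlorine again produced no step that can be told apart from the scatter of repeated measurements. Set side by side, the two steps agree, and in this assay the change carried over from one core to the other with the same outcome: the same change on two cores in this assay, a 1.1-fold lower number (0.04 log units; within the scatter) from compound 1 to compound 2 and a 1.3-fold lower number (0.12 log units; within the scatter) from compound 3 to compound 4, 1.2-fold (0.08 log units) apart, within the scatter of two such steps. This shows only that the move between these two chlorophenyl groups left the number within the scatter on both cores in this one cell assay; it does not show that the same would hold on a third core, in another cell line, or for any other change, and two pairs make a small sample.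

As far as these compounds go, all four compounds carry a chlorine on the phenyl ring, so it remains open what a plain phenyl, a methoxy group, a trifluoromethyl group or an amine would do in that place on either core. From the compounds shown here alone, it also remains open whether the outcome of moving a substituent around this ring would be the same for a group other than chlorine, such as a carboxylic acid.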